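From Hydroxy to Methoxy in Compound 3

A few compounds are considered here, and "the series" means these few. Any claim that something is new, unique, unknown or untested is made for them only; others in the source may bear on it.

In a functional assay on A549 cells (Homo sapiens) for antiproliferative activity, read by MTT assay, with a stated time of 48 h (on this read-out higher numbers stand for weaker inhibition and lower numbers for stronger inhibition), compound 1 `COc1cc(/C=N/c2c(C#N)ncn2-c2ccc(F)cc2)cc(OC)c1OC` gives 9880 nM, and compound 2 `COc1ccc(/C=N/c2c(C#N)ncn2-c2ccc(F)cc2)cc1` gives 17100 nM. These two values lie within the usual scatter of each other. Compound 3 `COc1ccc(/C=N/c2c(C#N)ncn2-c2ccc(F)cc2)cc1O` gives > 25000 nM, which is a limit of the assay and not a number. For the measured compounds named here, it is the only compound at that limit, as the limit of > 25000 nM in this assay, at which 1 of the 3 values shown sits, shows.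

Compound 4 `COc1ccc(/C=N/c2c(C#N)ncn2-c2ccc(F)cc2)cc1OC` turns the hydroxy of compound 3 into methoxy: methyl in place of hydrogen on an oxygen on an aromatic ring. Going by the values given here, the one measured step that bears on this is an at least 1.4-fold higher number from compound 2 to compound 3 (0.16 log units; that floor lies within the scatter), where hydroxy replaced hydrogen on an aromatic carbon. Compound 4 loses that hydroxy and carries only methoxy groups on that ring, like compound 1 at 9880 nM and compound 2 at 17100 nM. A number in the range of those two therefore seems likely, lower than the limit of compound 3. The expected change is an at least 1.9-fold lower number from compound 3 to compound 4 (0.28 log units; that floor lies within the scatter), an estimate that rests on a limit. For compound 4 the estimated value is 13000 nM, with an expected range from 7000 nM to 24000 nM.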

Compound 4, half-maximal inhibitory concentration: 2960 nM
The estimate for compound 4 lay 4.4-fold (0.64 log units) above the measured number, and the stated range ends above it.
By their numbers in this assay, from the lowest: compound 4; then compounds 1 and 2 (each within the scatter of the next). At a limit, above all of these: compound 3.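

In this assay, putting methyl on the oxygen of the hydroxy gives an at least 8.4-fold lower number from compound 3 to compound 4 (0.92 log units; beyond the scatter), so at this place on the ring a hydroxy and a methoxy are clearly not interchangeable. Compound 3 stands at a limit of the assay and not at a number: the limit of > 25000 nM in this assay, at which 1 of the 4 values shown sits. Adding a methoxy gives a 5.8-fold lower number from compound 2 to compound 4 (0.76 log units; beyond the scatter), yet taking a methoxy away gives a 3.3-fold lower number from compound 1 to compound 4 (0.52 log units; beyond the scatter), so adding methoxy groups does not lower the number at every step, and compound 1 goes against any such trend.

The compounds shown leave open whether a longer chain on that oxygen, such as ethyl, or an amine in place of the methoxy would keep the number this low. They also leave open the full size of the first step, which rests on a limit.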